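Methoxy for fluoro on a bis-benzylidene cyclohexanone

The source may hold more compounds than are shown below. What is called first, only, known or untested is meant among the compounds shown, and "the series" means these compounds.

Measured so far:
compound 1, `COc1ccc(/C=C2\CCC/C(=C\c3ccccc3[N+](=O)[O-])C2=O)cc1`, in a functional assay on CCRF-CEM cells (Homo sapiens) for cytotoxicity, with a stated time of 72 h (a higher number here means a weaker inhibitor, a lower number a stronger inhibitor), gives 7450 nM
compound 2, `O=C1/C(=C/c2ccc(F)cc2)CCC/C1=C\c1ccc([N+](=O)[O-])cc1`, in this assay gives 18600 nM

Compound 2 stands at the higher of the two numbers in this assay; the nearest point is compound 1, whose number is lower by a margin beyond the scatter. Going by the values given here, compound 1 and compound 2 differ in more than one place, so their pair gives no single step and nothing can be read from it about any one change.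

The next compound is compound 3, `COc1ccc(/C=C2\CCC/C(=C\c3ccc([N+](=O)[O-])cc3)C2=O)cc1`, not yet measured in this assay. It differs from compound 2 by one change: methoxy in place of fluoro on an aromatic carbon, para to a large group.

Among the compounds with values here, no step for this change exists among the measured compounds. Within the data shown here, the only methoxy-bearing compound, compound 1, sits at the lower number, but it is not a clean comparison. The step of a 1.7-fold lower number from compound 2 to compound 3 (0.23 log units; within the scatter) is therefore expected to be small to moderate toward a lower number, and it could also stay within the scatter. Compound 3 is estimated at 11000 nM, with a range from 4000 nM to 30000 nM.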

Compound 3, half-maximal inhibitory concentration in the CCRF-CEM assay: 250000 nM
Compound 3: the middle estimate sits 23-fold (1.36 log units) below what was measured; the measured number lies above the stated range.
By their numbers in the CCRF-CEM assay, from the lowest: compound 1; then compound 2; then compound 3.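

Methoxy in place of fluoro on an aromatic carbon, para to a large group, proves to be far from a neutral exchange in this series: in the CCRF-CEM assay the change gives a 13-fold higher number from compound 2 to compound 3 (1.13 log units; beyond the scatter), with compound 2 at 18600 nM and compound 3 at 250000 nM. In a physicochemical assay for lipophilicity (a lower number here means a more polar compound, a higher number a more lipophilic compound), the same change gives no change at the digits printed from compound 2 to compound 3 (within the scatter), with compound 2 at 5.08 and compound 3 at 5.08, so the two read-outs part ways for this pair. In the CCRF-CEM assay compound 3 now has the highest number of the three, while compound 1, which also carries the 4-methoxyphenyl group, gives 7450 nM, so that group does not go with a low number across these compounds. Nothing at hand accounts for the size of the step.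

Still open, from the compounds shown here alone, is whether the step belongs to methoxy in particular, since a hydroxyl, a chloro or an amine at the same place would separate that group from other replacements for fluoro. Also open is whether the exchange carries over to the arrangement of compound 1, for which the 4-fluorophenyl partner is not among the compounds shown.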